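This account rests on a few compounds, and the source may have more. Where it says the series, first, only, none or still open, it means among the compounds named here.

For the measured compounds named here, compound 3 `CN(C)CCCCCSC1=Nc2ccccc2C(CC(=O)NCc2ccccc2)N1c1ccc(-c2ccc(F)cc2)cc1` gives 250 nM in an assay on cells for inhibition of Voltage-dependent T-type calcium channel subunit alpha-1G (Homo sapiens), read by patch clamp (a lower number here means a stronger inhibitor, a higher number a weaker inhibitor), the lowest of the three numbers measured so far: compound 1 `CN(C)CCCCCSC1=Nc2ccccc2C(CC(=O)NCc2ccc(F)cc2)N1c1ccc(-c2ccccc2)cc1` gives 27400 nM and compound 2 `O=C(CC1c2ccccc2N=C(SCCCCCN2CCCC2)N1c1ccc(-c2ccccc2)cc1)NCc1ccc(F)cc1` gives 15000 nM, both far weaker. Going by the values given here, the only measured step, a 1.8-fold lower number from compound 1 to compound 2 (0.26 log units; within the scatter), concerns the amine at the end of the chain and says nothing about the group that changes here. Compound 4 `CN(C)CCCCCSC1=Nc2ccccc2C(CC(=O)NCc2ccccc2)N1c1ccccc1` differs from compound 3 in one place: hydrogen in place of 4-fluorophenyl on an aromatic carbon. Among the compounds with values here, the 4-fluorophenyl is a large group, and no measured pair shows what removing it does, so the expectation rests only on how much is taken away. Compound 4 is therefore expected to be weaker, with a step of a 12-fold higher number from compound 3 to compound 4 (1.08 log units; beyond the scatter) and a value estimated at 3000 nM, between 500 nM and 20000 nM.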

Compound 4, half-maximal inhibitory concentration: 18500 nM
For compound 4 the middle estimate is 6.2-fold (0.79 log units) below the measured one, within the range that was stated.
By their numbers in this assay, from the lowest: compound 3; then compounds 2, 4 and 1 (each within the scatter of the next).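

In this assay the 4-fluorophenyl on this aromatic carbon carries much of the strength: hydrogen in its place gives a 74-fold higher number from compound 3 to compound 4 (1.87 log units; beyond the scatter) and this is the first single change shown to go beyond the scatter. For the compounds shown here, the only earlier step, at the amine on the end of the chain, stayed within it. Nothing measured here explains why this group counts for so much. Still open, as far as these compounds go, is how much of the effect belongs to the fluorine and how much to the phenyl ring it sits on. Also open, from the compounds shown here alone, is whether a smaller group here, such as methyl or chlorine, would recover any of the lost strength.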